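This account rests on a few compounds, and the source may have more. Where it says the series, first, only, none or still open, it means among the compounds named here.

Of the compounds shown here, two of a shared core have been measured in a functional assay on 786-0 cells (Homo sapiens) for inhibition, read by sulforhodamine B assay, with a stated time of 48 h, tested at 10 uM; a higher number here means more inhibition at the concentration tested (going by the name of the read-out), a lower number less inhibition. Compound 1 `CCc1ccc(-c2cn3ccnc3c(-c3ccc4ncn(Cc5ccccc5)c4c3)n2)cc1` gives 38.1%, and compound 2 `O=Cc1ccc(-c2cn3ccnc3c(-c3ccc4ncn(Cc5ccccc5)c4c3)n2)cc1` gives 46.7%. Among these two numbers compound 2 holds the higher one, yet the single step, a number 8.6 percentage points higher from compound 1 to compound 2 (within the scatter), stays within the scatter, so the two cannot be ranked.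

The next compound, compound 3 `c1ccc(Cn2cnc3ccc(-c4nc(-c5cccc6ccccc56)cn5ccnc45)cc32)cc1`, has not yet been measured. It arises from compound 2 through (naphthalen-1-yl in place of 4-formylphenyl on an aromatic carbon). For the measured compounds named here, only one measured step touches the same aromatic carbon, the swap of formyl for ethyl, and it moved the read-out by a small amount. Going by the values given here, no measured step exchanges one aryl group for another, so the swap to naphthalen-1-yl rests on that single small change alone. A shift within the scatter is therefore expected, and compound 3 is estimated at 41%, spanning 24% to 58%. The step expected is a number 5.7 percentage points lower from compound 2 to compound 3 (within the scatter).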

Compound 3, a percentage reported as inhibition, at one concentration (the size of the read-out at that concentration, not a potency): 12.4%
Compound 3: the middle estimate sits 28.6 percentage points above what was measured; the whole stated range lies above it.
By their numbers in this assay, from the lowest: compound 3; then compounds 1 and 2 (each within the scatter of the next).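

This aromatic carbon of the shared core is sensitive to the group it carries. In this assay, naphthalen-1-yl in place of 4-formylphenyl gives a clear drop (a number 34.3 percentage points lower from compound 2 to compound 3 (beyond the scatter)), and in place of 4-ethylphenyl gives another (a number 25.7 percentage points lower from compound 1 to compound 3 (beyond the scatter)). For the compounds shown here, compound 1 and compound 2 differ only in the group on the phenyl ring and could not be ranked, so these two steps are the first sign that exchanging the whole aryl group matters here, though nothing available explains the fall.

Only this one two-ring group is shown, so it stays open whether a second fused ring in general lowers the read-out or only this particular attachment does. Naphthalen-2-yl, unsubstituted phenyl, or a phenyl carrying an amine or a carboxylic acid on this carbon would help separate those readings.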